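A few compounds are considered here, and "the series" means these few. Any claim that something is new, unique, unknown or untested is made for them only; others in the source may bear on it.

Measured in a functional assay on NCI-H460 cells (Homo sapiens) for cytotoxicity, read by MTT assay, with a stated time of 72 h; a lower number here means a stronger inhibitor, a higher number a weaker inhibitor:
compound 1 `CCCCNC1=CC(=O)C=C(C(C)(C)C)C1=O`: 14000 nM
compound 2 `CCCCCCCCNC1=CC(=O)C=C(C(C)(C)C)C1=O`: 20000 nM
compound 3 `CNC1=CC(=O)C=C(C(C)(C)C)C1=O`: 25000 nM

Compound 3 cannot be separated from the other two on these numbers. The record shows a 1.8-fold higher number from compound 1 to compound 3 (0.25 log units; within the scatter) and a 1.3-fold higher number from compound 2 to compound 3 (0.10 log units; within the scatter), so it holds no firm rank among them.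

Compound 4 `CC(C)(C)C1=CC(=O)C=CC1=O` has hydrogen in place of methylamino on a double-bonded ring carbon. Each measured step only alters the chain on the amine nitrogen, and the third, a 1.4-fold higher number from compound 1 to compound 2 (0.15 log units; within the scatter), is just as small. These steps show that chain length, across these three compounds, moves this assay very little. None of them removes the amino group, so they set no size for this change and give it no measured direction.

A modest move towards a lower number is expected, held with little confidence. The expected step is a 2.5-fold lower number from compound 3 to compound 4 (0.40 log units; beyond the scatter). For compound 4 the estimated value is 10000 nM, with an expected range from 2000 nM to 40000 nM.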

Compound 4, half-maximal inhibitory concentration: > 100000 nM
Compound 4: no number, only a limit; the forecaster's own chance of this, stated with the estimate: 10%; middle value at least 10-fold (1.00 log units) from the limit.
By their numbers in this assay, from the lowest: compounds 1, 2 and 3 (each within the scatter of the next). At a limit, above all of these: compound 4.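

In this assay, the record gives an at least 4.0-fold higher number from compound 3 to compound 4 (0.60 log units; beyond the scatter) and an at least 7.1-fold higher number from compound 1 to compound 4 (0.85 log units; beyond the scatter), for hydrogen in place of methylamino and of butylamino on a double-bonded ring carbon. Among these compounds, these are the first steps beyond the scatter in this set: changing the chain on the amine nitrogen across compounds 1, 2 and 3 did not separate them, whereas losing the whole amino group does separate compound 4 from compounds 1 and 3. The reading for compound 4 is a limit and not a number: the limit of > 100000 nM in this assay, at which 1 of the 4 values shown sits.

On these data alone, the true size of these steps therefore stays open. As far as these compounds go, it also remains open whether a hydroxyl group, a methoxy group or a dimethylamino group on that ring carbon would keep the number close to that of compound 3 or lose it as hydrogen does.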